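The compounds below may be only part of what the source reports. "The series", "measured", "known", "first", "only" and "open" are said of these compounds alone.

Compound 1 `O=C(C1CCC1)N1CC2CC(C1)N2`: in an assay on CHO cells for displacement of a labelled ligand from Neuronal acetylcholine receptor; alpha3/alpha6/beta2/beta3 (Homo sapiens), read by scintillation counting (a lower number here means a stronger inhibitor, a higher number a weaker inhibitor), compound 1 gives 240 nM
Compound 2 `O=C([C@H]1C[C@@H]1F)N1CC2CC(C1)N2`: in this assay compound 2 gives 490 nM

Compound 2 has the higher of these two numbers, so it is the weaker binder of the pair. Among the measured compounds shown here, the only measured step is a 2.0-fold higher number from compound 1 to compound 2 (0.31 log units; beyond the scatter), a modest shift in which the ring on the carbonyl carbon was changed. Compound 3 `C[C@@H]1C[C@H]1C(=O)N1CC2CC(C1)N2` differs from compound 2 in a single place: 2-methylcyclopropyl in place of 2-fluorocyclopropyl on a carbonyl carbon. For the measured compounds named here, no measured step covers an exchange of fluorine for methyl on that ring, so the step from compound 1 to compound 2 bears on it only loosely, by showing that changes of this small group move the number a little, not a lot. The expected step of a 1.5-fold lower number from compound 2 to compound 3 (0.17 log units; within the scatter) for compound 3 is therefore small, likely within the scatter or a slight drop back toward compound 1. For compound 3 the estimated value is 330 nM, expected to lie between 130 nM and 850 nM.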

Compound 3, inhibition constant: 14 nM
For compound 3 the middle estimate is 24-fold (1.37 log units) above the measured one; measured number outside the range, below it.
By their numbers in this assay, from the lowest: compound 3; then compound 1; then compound 2.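

Small changes at this position can matter far more than the earlier pair suggested. Exchanging 2-fluorocyclopropyl for 2-methylcyclopropyl on the carbonyl carbon gives a 35-fold lower number from compound 2 to compound 3 (1.54 log units; beyond the scatter) even though both groups have the same heavy-atom count and the same three-membered ring. The 2-methylcyclopropyl group also outperforms cyclobutyl, with a 17-fold lower number from compound 1 to compound 3 (1.23 log units; beyond the scatter) so that compound 3 is the strongest binder of the three in this assay and nothing available accounts for this large gain.

Going by these compounds, whether the gain would persist with an ethyl, a hydroxymethyl or a nitrile on the ring in place of the methyl remains open. Also open, on these data alone, is how the other stereoisomers of the 2-methylcyclopropyl group would compare with compound 3.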